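Dimethylamino in place of hydroxy on a shared core

A few compounds are considered here, and "the series" means these few. Any claim that something is new, unique, unknown or untested is made for them only; others in the source may bear on it.

Measured in a functional assay on SF-268 cells (Homo sapiens) for inhibition; on this read-out higher numbers stand for weaker inhibition of growth and lower numbers for stronger inhibition of growth:
- compound 1 `NS(=O)(=O)c1ccc(/C=C/c2ccc(O)c(O)c2)cc1`: 18200 nM
- compound 2 `NS(=O)(=O)c1ccc(/C=C/c2ccc(F)cc2)cc1`: 20500 nM
- compound 3 `NS(=O)(=O)c1ccc(/C=C/c2ccc(O)cc2)cc1`: 31500 nM

Compound 3, at 31500 nM, lies within the scatter of both other compounds, so the three values cannot be ranked. Compound 4 `CN(C)c1ccc(/C=C/c2ccc(S(N)(=O)=O)cc2)cc1` has dimethylamino in place of hydroxy on an aromatic carbon. The closest measured change is hydroxy in place of fluoro on an aromatic carbon, a 1.5-fold higher number from compound 2 to compound 3 (0.19 log units; within the scatter). The other change, hydrogen in place of hydroxy on an aromatic carbon, gave a 1.7-fold higher number from compound 1 to compound 3 (0.24 log units; within the scatter). Both steps stay within the scatter, but neither involves dimethylamino, so they offer only weak guidance. With compound 1, compound 2 and compound 3 so close in this assay, no step beyond the scatter is expected, and no direction is favoured with confidence. The estimate amounts to an expected 1.6-fold lower number from compound 3 to compound 4 (0.20 log units; within the scatter). Compound 4 is expected at 20000 nM, with an estimated range from 6000 nM to 50000 nM.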

Compound 4, concentration for 50% growth inhibition: 7160 nM
Beside the measured number, compound 4's estimate is 2.8-fold (0.45 log units) above it; low and high end bracket the measured number.
By their numbers in this assay, from the lowest: compound 4; then compounds 1, 2 and 3 (each within the scatter of the next).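

In this assay, placing dimethylamino on this aromatic carbon gives a 4.4-fold lower number from compound 3 to compound 4 (0.64 log units; beyond the scatter) and, set against fluoro at the same place, a 2.9-fold lower number from compound 2 to compound 4 (0.46 log units; beyond the scatter). Among these compounds, the earlier exchange at this position, hydroxy in place of fluoro, stayed within the scatter, so these two steps are the first sign that growth inhibition responds to the group placed here. Both are modest in size and both point towards stronger inhibition of growth, but nothing available here explains the gain.

From the compounds shown here alone, it remains open whether the gain would persist with a plain amino group, a methoxy group or a cyclic amine such as morpholine. Also open, going by these compounds, is whether the same exchange would hold on the core of compound 1, with its additional hydroxy.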